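Swapping Indole for Phenyl on a Receptor Antagonist Chain

This account rests on a few compounds, and the source may have more. Where it says the series, first, only, none or still open, it means among the compounds named here.

Measured so far:
compound 1 `COc1ccc(Cn2c(CCc3c[nH]c4ccccc34)nnc2[C@H](NC(=O)c2ccccn2)c2c[nH]c3ccccc23)cc1`: 102 nM
compound 2 `COc1ccc(Cn2c(CCc3ccccc3)nnc2[C@H](NC(=O)c2ccccn2)c2c[nH]c3ccccc23)cc1`: 12 nM
compound 3 `COc1ccc(Cn2c(CCc3c[nH]c4ccccc34)nnc2[C@H](NC(=O)c2cnccn2)c2c[nH]c3ccccc23)c(OC)c1`: 97 nM

All three have been tested in a functional assay on CHO cells for antagonist activity at growth hormone secretagogue receptor type 1 (Homo sapiens); on this read-out lower numbers stand for stronger inhibition and higher numbers for weaker inhibition. Compound 1 and compound 2 share one core and differ in a single place: phenyl in place of 1H-indol-3-yl on a saturated chain carbon, two bonds along the chain from an aromatic carbon. That change gave an 8.5-fold lower number from compound 1 to compound 2 (0.93 log units; beyond the scatter). Compound 3 is built on a different core; how its core differs from that of compound 1 is not broken down here, and its value in this assay lies within the usual scatter of the value of compound 1.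

Compound 4 `COc1ccc(Cn2c(CCc3ccccc3)nnc2[C@H](NC(=O)c2cnccn2)c2c[nH]c3ccccc23)c(OC)c1` has not yet been measured. It relates to compound 3 as compound 2 relates to compound 1: phenyl in place of 1H-indol-3-yl on a saturated chain carbon, two bonds along the chain from an aromatic carbon, the same change made at the same place. For the measured compounds named here, because the only earlier instance of this change gave an 8.5-fold lower number from compound 1 to compound 2 (0.93 log units; beyond the scatter), a step of similar size is expected here, namely a 7.5-fold lower number from compound 3 to compound 4 (0.87 log units; beyond the scatter). On that basis compound 4 is estimated at 13 nM, with a likely range from 5 nM to 35 nM. The expectation rests on one earlier pair only and is held loosely.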

Compound 4, antagonist equilibrium constant: 24 nM
Estimate against measurement, compound 4: 1.8-fold (0.27 log units) below; low and high end bracket the measured number.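

In this assay, putting phenyl in place of 1H-indol-3-yl on the core of compound 3 gives a 4.0-fold lower number from compound 3 to compound 4 (0.61 log units; beyond the scatter) and so moves the number in the same direction as the same change did on the core of compound 1. The two steps agree in direction, and the gap between their sizes is no larger than repeat measurements would produce, so on these two cores the change carries over as one effect: the same change on two cores in this assay, an 8.5-fold lower number (0.93 log units; beyond the scatter) from compound 1 to compound 2 and a 4.0-fold lower number (0.61 log units; beyond the scatter) from compound 3 to compound 4, 2.1-fold (0.32 log units) apart, within the scatter of two such steps. For the compounds shown here, this rests on only two pairs of compounds, so it does not show that the change would work the same way on any further core, and it says nothing about why phenyl gives the lower number.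

On these data alone, what remains open is how much of the effect depends on the exact group at this place. A longer chain ending in phenyl, a phenyl ring carrying a chlorine atom, or a saturated cyclohexyl ring in place of the phenyl could each help to answer that.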